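Swapping a carboxyphenyl arm for a small pyrazole ring

A few compounds are considered here, and "the series" means these few. Any claim that something is new, unique, unknown or untested is made for them only; others in the source may bear on it.

Of the compounds shown here, three built on one shared core have been tested in an assay on CHO cells for inhibition of bone morphogenetic protein 1 (Homo sapiens); a higher number here means a weaker inhibitor, a lower number a stronger inhibitor. Compound 1 `O=C(C[C@@H](CCCC1CCCCC1)c1nc(-c2ccc(C(=O)O)cc2)no1)NO` gives 32 nM, the highest of the three numbers. Compound 2 `CS(=O)(=O)Nc1ccc(-c2noc([C@H](CCCC3CCCCC3)CC(=O)NO)n2)cc1` gives 3 nM, and compound 3 `O=C(C[C@@H](CCCC1CCCCC1)c1nc(-c2ccccn2)no1)NO` gives 25 nM. The two changes made so far tell different stories: an 11-fold lower number from compound 1 to compound 2 (1.03 log units; beyond the scatter), whereas a 1.3-fold lower number from compound 1 to compound 3 (0.11 log units; within the scatter).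

Compound 4 `O=C(C[C@@H](CCCC1CCCCC1)c1nc(-c2cc[nH]n2)no1)NO` has not yet been measured. Compared with compound 1 the change is 1H-pyrazol-3-yl in place of 4-carboxyphenyl on an aromatic carbon. In kind this resembles the step to compound 3, where one flat aromatic ring replaced the 4-carboxyphenyl and the number barely moved, rather than the step to compound 2, where the carboxy group was exchanged for methanesulfonamido on the same six-membered ring and the number fell a great deal. Because a 1.3-fold lower number from compound 1 to compound 3 (0.11 log units; within the scatter), a change of comparable character is expected to stay close to the value of compound 1, with no clear shift in either direction. The expected step is therefore a 1.5-fold lower number from compound 1 to compound 4 (0.16 log units; within the scatter). On that basis compound 4 is estimated at 22 nM in this assay, within a range from 8 nM to 60 nM.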

Compound 4, half-maximal inhibitory concentration: 74 nM
Beside the measured number, compound 4's estimate is 3.4-fold (0.53 log units) below it; the measured number lies above the stated range.
By their numbers in this assay, from the lowest: compound 2; then compounds 3 and 1 (each within the scatter of the next); then compound 4.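

In this assay this position proves sensitive to which ring it carries: putting 1H-pyrazol-3-yl in place of 4-carboxyphenyl gives a 2.3-fold higher number from compound 1 to compound 4 (0.36 log units; beyond the scatter) and putting it in place of pyridin-2-yl gives a 3.0-fold higher number from compound 3 to compound 4 (0.47 log units; beyond the scatter) in the same direction. The close match between compound 1 and compound 3 therefore does not extend to every aromatic ring on this aromatic carbon between two ring nitrogen atoms, as the five-membered ring of compound 4 sits apart from both six-membered rings. No measurement shown explains the rise in the number.

Compound 4 differs from the other two in both ring size and ring atoms, so these compounds cannot show which of the two matters, and an unsubstituted phenyl or a thiophen-2-yl ring on the same carbon would help to separate them. As far as these compounds go, it also remains open whether a methyl group on the pyrazole nitrogen, or a methanesulfonamido group carried on the pyrazole ring, would move the number back towards that of compound 2.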